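A Benzyl Ester Added to an Unmoved Series

This account rests on a few compounds, and the source may have more. Where it says the series, first, only, none or still open, it means among the compounds named here.

Three compounds share one core and differ only in the chain on the aromatic nitrogen: compound 1 (`CCN(CC)C(=O)Cn1c(=O)c(-c2ccc(OC)cc2)cc2c(OC)cc(OC)cc21`), compound 2 (`COc1ccc(-c2cc3c(OC)cc(OC)cc3n(CC#N)c2=O)cc1`) and compound 3 (`COC(=O)CCn1c(=O)c(-c2ccc(OC)cc2)cc2c(OC)cc(OC)cc21`). In a functional assay on LoVo cells (Homo sapiens) for cytotoxicity, read by colorimetric assay and MTT assay (on this read-out lower numbers stand for stronger inhibition and higher numbers for weaker inhibition), compound 1 gives 10000 nM, compound 2 gives 10000 nM and compound 3 gives 10000 nM, so compound 3 stands level with the other two.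

Compound 4 (`COc1ccc(-c2cc3c(OC)cc(OC)cc3n(CCC(=O)OCc3ccccc3)c2=O)cc1`) differs from compound 3 in one place: phenyl in place of hydrogen on a saturated chain carbon bound to an oxygen next to a carbonyl group. This is phenyl in place of hydrogen on a saturated chain carbon bound to an oxygen next to a carbonyl group, which turns methoxycarbonyl into benzyloxycarbonyl.

For the measured compounds named here, no measured step makes this exact change, so the nearest evidence is three swaps on the same chain: no change at the digits printed from compound 1 to compound 2 (within the scatter), no change at the digits printed from compound 1 to compound 3 (within the scatter) and no change at the digits printed from compound 2 to compound 3 (within the scatter). As far as these compounds go, none of them moved the number, although a new aromatic ring remains untested in this set. The expected step in this assay is a 1.1-fold lower number from compound 3 to compound 4 (0.05 log units; within the scatter), with no shift beyond the scatter in either direction. For compound 4 the estimate is 9000 nM, with an expected range from 3500 nM to 14000 nM.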

Compound 4, half-maximal inhibitory concentration: 10000 nM
Compound 4: the middle estimate sits 1.1-fold (0.05 log units) below what was measured; the range from low to high includes it.
By their numbers in this assay, from the lowest: compounds 1, 2, 3 and 4 (each within the scatter of the next).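

In this assay, the new aromatic ring leaves the reading unmoved (no change at the digits printed from compound 3 to compound 4 (within the scatter)), so phenyl in place of hydrogen on a saturated chain carbon bound to an oxygen next to a carbonyl group adds to the three earlier swaps a change they did not test, and it too shows no effect. Set against the other two chains, the benzyloxycarbonyl compound reads the same (no change at the digits printed from compound 2 to compound 4 (within the scatter); no change at the digits printed from compound 1 to compound 4 (within the scatter)), so all four groups shown on this chain now stand together at one printed value. Nothing available here offers an explanation for this flat result.

As far as these compounds go, whether any group at this place can move the number remains open: an amine or a carboxylic acid on the chain would be one test. Also open, from the compounds shown here alone, is whether a change elsewhere on the shared core, such as a hydroxyl in place of a methoxy group, would register in this assay.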